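The source may hold more compounds than are shown below. What is called first, only, known or untested is meant among the compounds shown, and "the series" means these compounds.

Measured so far in an assay on HPBALL cells for binding affinity to C-X-C chemokine receptor type 4 (Homo sapiens), read by flow cytometry, with a stated time of 3 h; on this read-out lower numbers stand for stronger inhibition and higher numbers for weaker inhibition:
compound 1 `Cc1nc(CN2CCCCC2c2ccccn2)cc(N2CCN(C)CC2)n1` gives 620 nM
compound 2 `Cc1nc(CN2CCC(C)C2c2ccccn2)cc(N2CCN(C)CC2)n1` gives 1550 nM
compound 3 `Cc1ccnc([C@@H]2CCCN2Cc2cc(N3CCN(C)CC3)nc(C)n2)c1` gives 216 nM

Among these three, compound 3 has the lowest number. Its gap to compound 1, and its larger gap to compound 2, both go beyond the usual scatter of repeated measurements, so compound 3 counts as the strongest binder of the set. Compound 4 `Cc1ccc([C@@H]2CCCN2Cc2cc(N3CCN(C)CC3)nc(C)n2)nc1` has not yet been measured in this assay. It differs from compound 3 in a single place: 5-methylpyridin-2-yl in place of 4-methylpyridin-2-yl on a saturated ring carbon. The same atoms are present, only joined differently. Going by the values given here, none of the measured compounds shows what such a shift of the methyl does, so the expectation rests on the change being small: the step from compound 3 to compound 4 is expected to be a 1.4-fold higher number from compound 3 to compound 4 (0.14 log units; within the scatter), not clearly beyond the scatter. Compound 4 is therefore estimated to give about 300 nM, within a range from 100 nM to 900 nM.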

Compound 4, half-maximal inhibitory concentration: 278 nM
Compound 4: middle estimate off by 1.1-fold (0.03 log units), on the high side; measured number inside the range.
By their numbers in this assay, from the lowest: compounds 3 and 4 (each within the scatter of the next); then compound 1; then compound 2.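

Placing 5-methylpyridin-2-yl in place of 4-methylpyridin-2-yl on this saturated ring carbon gives, in this assay, a 1.3-fold higher number from compound 3 to compound 4 (0.11 log units; within the scatter). At this position, then, the two methyl placements cannot be told apart by this measurement. Nothing at hand offers an explanation for this result.

Whether the methyl contributes at all remains open, since the compounds shown include no pyridin-2-yl without it. Also open, from the compounds shown here alone, is how a methoxy group or an amine in place of the methyl would read out here.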